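Permeability notes: isopropyl to sec-butyl on the shared core

The source may report more compounds than this note shows. Statements on the series, on what has been measured and on what is new or still open speak of the compounds shown alone.

Compound 2 `CC(C)n1nc(N2CC(C(C)(C)O)C2)c2cnc(Nc3ccnc(-c4cnn(S(=O)(=O)C5CC5)c4)n3)cc21` gives 20 10^-6 cm/s in an ADME assay on MDCK cells (Canis lupus familiaris) for permeability, in the apical to basolateral direction (on this read-out higher numbers stand for higher permeability and lower numbers for lower permeability), and stands highest of the two numbers in hand, though only by a step within the scatter. Compound 1 `CC(C)n1nc(N)c2cnc(Nc3ccnc(-c4cnn(S(=O)(=O)C5CC5)c4)n3)cc21` gives 16 10^-6 cm/s in this assay; the step of a 1.3-fold higher number from compound 1 to compound 2 (0.10 log units; within the scatter) lies within the scatter. Compound 3 `CC[C@@H](C)n1nc(N2CC(C(C)(C)O)C2)c2cnc(Nc3ccnc(-c4cnn(S(=O)(=O)C5CC5)c4)n3)cc21` has not yet been measured. It differs from compound 2 by methyl in place of hydrogen on a saturated chain carbon, two bonds along the chain from an aromatic nitrogen; read one bond further out, the change is isopropyl to sec-butyl. Going by the values given here, no measured step touches this part of the structure: the single step in hand, a 1.3-fold higher number from compound 1 to compound 2 (0.10 log units; within the scatter), alters a different position and was within the scatter. On the two numbers available, no step beyond the scatter is expected for compound 3, and a 1.1-fold higher number from compound 2 to compound 3 (0.04 log units; within the scatter) is the estimated step. Compound 3 is therefore expected to give about 22 10^-6 cm/s in this assay, with a range from 11 10^-6 cm/s to 44 10^-6 cm/s.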

Compound 3, apparent permeability: 19 10^-6 cm/s
For compound 3 the middle estimate is 1.2-fold (0.06 log units) above the measured one; low and high end bracket the measured number.
By their numbers in this assay, from the lowest: compounds 1, 3 and 2 (each within the scatter of the next).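

Going by these compounds alone, this is the first step at the saturated chain carbon two bonds along the chain from an aromatic nitrogen: methyl in place of hydrogen, read one bond further out as isopropyl to sec-butyl, gives a 1.1-fold lower number from compound 2 to compound 3 (0.02 log units; within the scatter) in this assay. Within the data shown here, the earlier step altered a different position, so this single pair is the only reading at this place, and on it the two numbers stay within the scatter of each other. No evidence in hand bears on this result.

On these data alone, whether a longer chain, a cyclopropyl group, or a chain carrying a hydroxyl or an amine would read the same here remains open. Also open, as far as these compounds go, is whether methyl in place of hydrogen gives a similar step with the amino group of compound 1 on the shared core.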